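A few compounds are considered here, and "the series" means these few. Any claim that something is new, unique, unknown or untested is made for them only; others in the source may bear on it.

Compounds measured in an assay on blood for inhibition of C-X-C chemokine receptor type 3 (Homo sapiens), with a stated time of 30 min; on this read-out lower numbers stand for stronger inhibition and higher numbers for weaker inhibition:
compound 1, `CCOc1ncc(-c2nc(C(F)(F)F)sc2N2CCN(C(=O)Cn3ccc4cnccc43)[C@H](C)C2)cn1`: 25 nM
compound 2, `CCOc1ncc(-c2nc(C(F)(F)F)sc2N2CCN(C(=O)Cn3nc(C)nc3C)[C@H](C)C2)cn1`: 364 nM

Within the data shown here, compound 2 holds the higher of the two numbers; its only neighbour is compound 1, and the step of a 15-fold higher number from compound 1 to compound 2 (1.16 log units; beyond the scatter) is large and beyond the scatter. Compound 3, `Cc1nc(C)n(CC(=O)N2CCN(c3sc(C(F)(F)F)nc3-c3cnc(OC4CCC4)nc3)C[C@H]2C)n1`, keeps the whole amide side of compound 2 and differs in one place: cyclobutyl in place of ethyl on an oxygen on an aromatic ring. Among the measured compounds shown here, no measured step bears on this position. For the measured compounds named here, the single step so far, between compound 1 and compound 2, concerns the group on the saturated chain carbon bound to the carbonyl carbon and leaves the ethoxy untouched, so the ether has never been varied here. With nothing to anchor size or direction, the expected step is a 1.1-fold lower number from compound 2 to compound 3 (0.04 log units; within the scatter), none beyond the scatter. Compound 3 is therefore estimated at 330 nM, with a range from 110 nM to 1000 nM.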

Compound 3, half-maximal inhibitory concentration in the C-X-C chemokine receptor type 3 assay: 306 nM
Estimate against measurement, compound 3: 1.1-fold (0.03 log units) above; the measured number falls inside the stated range.
By their numbers in the C-X-C chemokine receptor type 3 assay, from the lowest: compound 1; then compounds 3 and 2 (each within the scatter of the next).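

In the C-X-C chemokine receptor type 3 assay, the first variation at this ether gives a 1.2-fold lower number from compound 2 to compound 3 (0.08 log units; within the scatter), so cyclobutyl in place of ethyl on an oxygen on an aromatic ring leaves no readable difference on the amide side of compound 2. The ether is therefore open to a larger, ring-bearing group in this pair, and the four-membered ring carries no penalty that this read-out can detect. In a physicochemical assay for lipophilicity, at pH 7.4 (on this read-out higher numbers stand for higher lipophilicity and lower numbers for lower lipophilicity), compound 2 gives 2.8 and compound 3 gives 3.6. With no readable return in the C-X-C chemokine receptor type 3 assay, the same change still registers in the physicochemical assay as higher lipophilicity: the measured distribution coefficient of compound 2, 2.8, and of compound 3, 3.6, a number 0.80 log units higher (beyond the scatter)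

From the compounds shown here alone, it remains open whether the ether change would behave alike on the amide side of compound 1, which gives 25 nM. Also open, going by these compounds, is whether a 2-methoxyethyl chain or an amine on this oxygen would keep the number in the C-X-C chemokine receptor type 3 assay while lowering the number in the physicochemical assay.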